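Three bromopyrrole chalcones all beyond the cytotoxicity limit

The compounds below may be only part of what the source reports. "The series", "measured", "known", "first", "only" and "open" are said of these compounds alone.

Measured so far:
Compound 1, `Cn1c(/C=C/C(=O)c2ccc[nH]2)cc(Br)c1Br`: in a functional assay on Caco-2 cells (Homo sapiens) for cytotoxicity, read by MTT assay, with stated times of 6 h and 48 h (on this read-out lower numbers stand for stronger inhibition and higher numbers for weaker inhibition), compound 1 gives >= 100000 nM, which is a limit of the assay and not a number.
Compound 2, `COc1ccc(OC)c(C(=O)/C=C/c2cc(Br)c(Br)n2C)c1`: in this assay compound 2 gives >= 100000 nM, again a limit of the assay.
Compound 3, `O=C(/C=C/c1cc(Br)c(Br)[nH]1)c1ccc[nH]1`: in this assay compound 3 gives >= 100000 nM, once more a limit.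

All three values sit at the same place, (the limit of >= 100000 nM in this assay, at which 3 of the 3 values shown sit), so no ordering among them can be read. Compound 1 and compound 3 differ by one change, (hydrogen in place of methyl on an aromatic nitrogen), and the step that the two limits leave unreadable from compound 1 to compound 3 cannot be sized, since both ends are limits. The difference between the core of compound 1 and the core of compound 2 is not broken down here.

Compound 4, `COc1ccc(OC)c(C(=O)/C=C/c2cc(Br)c(Br)[nH]2)c1`, is not yet measured. It arises from compound 2 by hydrogen in place of methyl on an aromatic nitrogen. This is the same kind of change as that from compound 1 to compound 3; around the place, the description for compound 2 names the ring atom that bears a large group, whereas for compound 1 it names the ring atom that bears a group of 9 heavy atoms. Because compound 2 already stands at >= 100000 nM and the matching step in the first pair is unreadable, the step of a number no higher from compound 2 to compound 4 (the limit leaves the size open) is expected to be close to nil, and compound 4 is most likely to return only another limit. The estimate for compound 4 in this assay is 100000 nM, expected between 50000 nM and 200000 nM.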

Compound 4, half-maximal inhibitory concentration: >= 100000 nM
Compound 4 gave a limit, no number; the forecaster's own chance of this, stated with the estimate: 85%; the middle value sits exactly at the limit.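

In this assay compound 4 gives >= 100000 nM as a limit of the assay and not a number. Within the data shown here, compound 2 and compound 4 therefore add no step that can be read, since both ends are limits. All the values shown sit at one place: (the limit of >= 100000 nM in this assay, at which 4 of the 4 values shown sit). The compounds shown leave open how far any of them lies from that limit, and whether hydrogen in place of methyl on the aromatic nitrogen changes this read-out at all.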